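Cyano for chloro: projecting compound 3 from compound 1

The source may hold more compounds than are shown below. What is called first, only, known or untested is meant among the compounds shown, and "the series" means these compounds.

Of the compounds shown here, two have been measured. Compound 1 `N#Cc1cc(Cl)ccc1NC(=O)c1ccc2cccnc2c1O` and compound 2 `O=C(Nc1cc(C(F)(F)F)cc(C(F)(F)F)c1)c1ccc(-c2ccccc2)cc1O` were both run in a functional assay on HL-60 cells (Homo sapiens) for cytotoxicity, read by luminescence and CellTiter-Glo, with a stated time of 3 days; a higher number here means a weaker inhibitor, a lower number a stronger inhibitor. In this assay compound 1 gives 790 nM, the lowest of the two numbers, while compound 2 gives 1140 nM; the gap between the two lies within the scatter, so no order between them can be stated. Among the compounds with values here, compound 1 and compound 2 differ in more than one place, so no single step between measured compounds is available as a guide.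

Compound 3 `N#Cc1ccc(NC(=O)c2ccc3cccnc3c2O)c(C#N)c1` has not yet been measured. It differs from compound 1 in one place: cyano in place of chloro on an aromatic carbon. Within the data shown here, no measured step of this kind exists, so the expectation rests on compound 1 alone. Exchanging chloro for cyano on that aromatic carbon is expected to move the number little, with no clear direction, and most likely not beyond the scatter. For compound 3 the value in this assay is estimated at 800 nM, with a range from 300 nM to 2200 nM. The step of a 1.0-fold higher number from compound 1 to compound 3 (0.01 log units; within the scatter) that this estimate implies is expected to sit within the usual scatter.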

Compound 3, half-maximal inhibitory concentration: 890 nM
Compound 3: middle estimate off by 1.1-fold (0.05 log units), on the low side; low and high end bracket the measured number.
By their numbers in this assay, from the lowest: compounds 1, 3 and 2 (each within the scatter of the next).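

In this assay, within the data shown here, the exchange of chloro for cyano on this aromatic carbon gives a 1.1-fold higher number from compound 1 to compound 3 (0.05 log units; within the scatter) and so provides the first single-place step, which the comparison of compound 1 with compound 2 could not supply. At this position, para to a large group and meta to a cyano group, one heavy atom with no hydrogen-bond acceptor can give way to two heavy atoms with one hydrogen-bond acceptor, with no change that can be read from the numbers. No measured property in hand bears on this result, and nothing here accounts for it.

Whether the position remains as undemanding for groups of other kinds, such as an amine, a carboxylic acid or a longer chain, stays open, since the compounds shown carry only chloro and cyano there. Also open, from the compounds shown here alone, is whether the same exchange would give a similar step without the neighbouring features of the shared core, including the cyano group that compound 1 and compound 3 have in common.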